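A few compounds are considered here, and "the series" means these few. Any claim that something is new, unique, unknown or untested is made for them only; others in the source may bear on it.

In a functional assay on CCRF-CEM cells (Homo sapiens) for inhibition (a lower number here means a stronger inhibitor, a higher number a weaker inhibitor), compound 3 `OC[C@H]1OC(n2cnc3c(-c4cc5ccccc5o4)ncnc32)[C@H](O)[C@@H]1O` gives the highest number of the series at 15000 nM, with compound 1 `Cc1ccsc1-c1ncnc2c1ncn2C1O[C@H](CO)[C@@H](O)[C@H]1O` at 2500 nM and compound 2 `OC[C@H]1OC(n2cnc3c(-c4ccc(F)cc4)ncnc32)[C@H](O)[C@@H]1O` at 700 nM. Compound 4 `OC[C@H]1OC(n2cnc3c(-c4ccsc4)ncnc32)[C@H](O)[C@@H]1O` has thiophen-3-yl in place of 1-benzofuran-2-yl on an aromatic carbon. Two measured steps introduce the leaving group, the large 21-fold higher number from compound 2 to compound 3 (1.33 log units; beyond the scatter) and the modest 6.0-fold higher number from compound 1 to compound 3 (0.78 log units; beyond the scatter). Between the other two groups lies the modest 3.6-fold lower number from compound 1 to compound 2 (0.55 log units; beyond the scatter). Losing 1-benzofuran-2-yl should therefore lower the number, with 3-methylthiophen-2-yl in compound 1 at 2500 nM as the closest measured reference. The expected step is a 15-fold lower number from compound 3 to compound 4 (1.18 log units; beyond the scatter), which would be large. For compound 4 the estimate is 1000 nM, within an expected range of 200 nM to 4000 nM.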

Compound 4, half-maximal inhibitory concentration: 1640 nM
The estimate for compound 4 lay 1.6-fold (0.21 log units) below the measured number; measured number inside the range.
By their numbers in this assay, from the lowest: compound 2; then compounds 4 and 1 (each within the scatter of the next); then compound 3.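

In this assay, thiophen-3-yl, with one five-membered aromatic ring where 1-benzofuran-2-yl also carries a six-membered one, shows a clear change at this aromatic carbon (a 9.1-fold lower number from compound 3 to compound 4 (0.96 log units; beyond the scatter)). Thiophen-3-yl and 3-methylthiophen-2-yl cannot be told apart here (a 1.5-fold lower number from compound 1 to compound 4 (0.18 log units; within the scatter)), whereas 4-fluorophenyl remains distinct from thiophen-3-yl (a 2.3-fold higher number from compound 2 to compound 4 (0.37 log units; beyond the scatter)). No measurement at hand gives a cause for these steps.

On these data alone, how an amine or a carboxylic acid on this aromatic carbon would compare with these aromatic groups remains open.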